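Swapping pyrrolidinyl for methoxy: expected Vero cell tolerance

The source may report more compounds than this note shows. Statements on the series, on what has been measured and on what is new or still open speak of the compounds shown alone.

Compound 1 `Nc1ccn2nc(-c3ccc(F)cc3)c(-c3ccnc(NC4CCCC4)n3)c2c1` gives 20000 nM in an ADME assay on Vero cells (Chlorocebus sabaeus) for cytotoxicity; a higher number here means that more compound is tolerated, a lower number that less compound is tolerated.
Compound 2 `Fc1ccc(-c2nn3ccc(N4CCCC4)cc3c2-c2ccnc(NC3CCCC3)n2)cc1` gives > 40000 nM, which is a limit of the assay.
Compound 3 `COc1ccc(-c2nn3c(SC(C)C)cc(NC4CCCC4)cc3c2-c2ccnc(NC3CCCC3)n2)cc1` gives > 40000 nM, again a limit of the assay.

Compound 2 therefore stands at the top of what this assay can report: its number is a limit, not a measured concentration, and it shares that position with compound 3, as the observation of the limit of > 40000 nM in this assay, at which 2 of the 3 values shown sit, makes plain. Among the measured compounds shown here, only one measured step touches the site of interest: going from compound 1 to compound 2 gave an at least 2.0-fold higher number from compound 1 to compound 2 (0.30 log units; that floor lies within the scatter), a step whose floor lies within the usual scatter, so it cannot be called a real change.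

Compound 4 `COc1ccn2nc(-c3ccc(F)cc3)c(-c3ccnc(NC4CCCC4)n3)c2c1` differs from compound 2 by methoxy in place of pyrrolidin-1-yl on an aromatic carbon. Methoxy is a smaller group than pyrrolidin-1-yl, and the nearest comparison is compound 1, where a small amino group at the same place gave 20000 nM. The expectation is therefore a number that may fall just below the limit, but not far from it. For compound 4 the estimate in this assay is 35000 nM, within 15000 nM to 80000 nM, which is expected to amount to an at least 1.1-fold lower number from compound 2 to compound 4 (0.05 log units; that floor lies within the scatter).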

Compound 4, half-maximal cytotoxic concentration: > 36000 nM
Compound 4 ended at the assay's limit; the forecaster's own chance of this, stated with the estimate: 40%; middle value at least 1.0-fold (0.01 log units) away from the limit.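

In this assay, compound 4 ends at a limit rather than at a measured concentration: the limit of > 36000 nM in this assay, at which 1 of the 4 values shown sits. Compound 2 also stands at a limit, so the swap of pyrrolidin-1-yl for methoxy cannot be read, and nothing can be said about which of the two groups is better tolerated. What is new is that at this place, opposite the ring nitrogen, a group with no ring also reaches a limit, so the five-membered ring of pyrrolidin-1-yl is not needed for that outcome in compound 4; set against the amino group, methoxy gives an at least 1.8-fold higher number from compound 1 to compound 4 (0.25 log units; that floor lies within the scatter), and because the floor of that step lies within the scatter, it does not establish a real change.

On these data alone, the true numbers behind the limits for compound 2 and compound 4 stay unknown, as does whether the amino group of compound 1 truly lowers tolerance at all. Also open, as far as these compounds go, is whether a quite different group at this place, such as a carboxylic acid, a basic amine or a longer chain like hexyloxy, would give a number clearly below these limits.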